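Hydroxy added to the shared core of three lactone-ring analogues

The source may report more compounds than this note shows. Statements on the series, on what has been measured and on what is new or still open speak of the compounds shown alone.

Compound 1, `COc1ccc(C[C@H]2COC(=O)[C@@H]2Cc2ccc(Cl)c(Cl)c2)cc1`, gives 37000 nM in a functional assay on HL-60 cells (Homo sapiens) for cytotoxicity, read by WST assay, with a stated time of 48 h; a higher number here means that more compound is needed for the effect, a lower number that less compound is needed.
Compound 2, `COc1ccc(C[C@H]2COC(=O)[C@@H]2Cc2ccc(Cl)c(Cl)c2)cc1O`, gives 32000 nM in this assay.
Compound 3, `COc1ccc(C[C@H]2COC[C@@H]2Cc2ccc(Cl)c(Cl)c2)cc1`, gives 39000 nM in this assay.

All three numbers sit close together, and none of the three compounds can be set apart from the others on this evidence. Within the data shown here, the one change that has already been measured is hydroxy in place of hydrogen on an aromatic carbon, and it gave a 1.2-fold lower number from compound 1 to compound 2 (0.06 log units; within the scatter), a step that stays inside the usual scatter of this kind of measurement.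

Compound 4, `COc1ccc(C[C@H]2COC[C@@H]2Cc2ccc(Cl)c(Cl)c2)cc1O`, has not yet been measured. It stands to compound 3 as compound 2 stands to compound 1: the change is hydroxy in place of hydrogen on an aromatic carbon, the same kind of change, made at a place that is described in the same words for both pairs. Among the measured compounds shown here, the difference between the two cores, that of compound 1 and that of compound 3, is not broken down here; what can be said is only that compound 1 and compound 3 give numbers within the scatter of each other.

Because the earlier step was a 1.2-fold lower number from compound 1 to compound 2 (0.06 log units; within the scatter), and because compound 3 gives 39000 nM, the expected step in this assay is a 1.1-fold lower number from compound 3 to compound 4 (0.06 log units; within the scatter), small and inside the scatter. Compound 4 is therefore estimated at 34000 nM, with a likely range from 17000 nM to 68000 nM.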

Compound 4, half-maximal effective concentration: 33000 nM
Compound 4: middle estimate off by 1.0-fold (0.01 log units), on the high side; the range from low to high includes it.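

In this assay, hydroxy in place of hydrogen on an aromatic carbon gives a 1.2-fold lower number from compound 3 to compound 4 (0.07 log units; within the scatter), and this step can be set directly beside the one seen earlier on the core of compound 1: the same change on two cores in this assay, a 1.2-fold lower number (0.06 log units; within the scatter) from compound 1 to compound 2 and a 1.2-fold lower number (0.07 log units; within the scatter) from compound 3 to compound 4, 1.0-fold (0.01 log units) apart, within the scatter of two such steps. For these two cores, then, the change behaves the same way, and nothing in the numbers separates its outcome on one core from its outcome on the other. This is a weak test of carrying a change across, however: both steps lie within the scatter, so what carries over is only the absence of a readable effect, and the data show neither that hydroxy has a real effect on this cytotoxicity read-out nor that the match would hold on any further core.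

The compounds shown leave open what an amine or a carboxylic acid would do at the same place, ortho to a methoxy group, and whether a step large enough to read would also match across the two cores. They also leave open whether a longer chain in place of the methoxy group would move the number beyond the scatter on either core.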